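A Trifluoromethyl Step From Compound 1 in Cells

The compounds below may be only part of what the source reports. "The series", "measured", "known", "first", "only" and "open" are said of these compounds alone.

Within the data shown here, in a functional assay on MCF7 cells (Homo sapiens) for inhibition, read by MTT assay, with a stated time of 72 h (a lower number here means a stronger inhibitor, a higher number a weaker inhibitor), compound 1 (`O=C(Nc1ccccc1)C1CCN(C/C=C/c2ccccc2)CC1`) gives 60200 nM, the higher of the two numbers measured so far, and compound 2 (`CCCCCc1ccc(NC(=O)C2CCN(C/C=C/c3ccccc3)CC2)cc1`) gives 3740 nM. Compound 3 (`O=C(Nc1cccc(C(F)(F)F)c1)C1CCN(C/C=C/c2ccccc2)CC1`) has trifluoromethyl in place of hydrogen on an aromatic carbon, meta to a large group (trifluoromethyl in place of hydrogen on an aromatic carbon). Among the measured compounds shown here, the only measured step, a 16-fold lower number from compound 1 to compound 2 (1.21 log units; beyond the scatter), is large and brings pentyl in place of hydrogen on an aromatic carbon. It involves a different group, so a smaller step towards a lower number is expected. The expected change is a 3.0-fold lower number from compound 1 to compound 3 (0.48 log units; beyond the scatter). Compound 3 is estimated at 20000 nM, with an expected range of 7000 nM to 60000 nM.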

Compound 3, half-maximal inhibitory concentration: 16100 nM
Compound 3: the middle estimate sits 1.2-fold (0.09 log units) above what was measured, within the range that was stated.
By their numbers in this assay, from the lowest: compound 2; then compound 3; then compound 1.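

In this assay, trifluoromethyl on an aromatic carbon, meta to a large group, gives a 3.7-fold lower number from compound 1 to compound 3 (0.57 log units; beyond the scatter) in a modest step. Pentyl is therefore not the only group on this aromatic ring of the core of compound 1 that goes with a lower number, and neither of the two substitutions shown goes against this. Nothing at hand bears on why the number falls.

The compounds shown leave open whether an amine or a carboxylic acid in the same place would also lower the number. They also leave open how far a longer chain or a nitrile would carry it.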